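The source may hold more compounds than are shown below. What is called first, only, known or untested is meant among the compounds shown, and "the series" means these compounds.

The shared core is carried by compound 1 `CN(C)C(=O)c1cc2cnc(Nc3ccc(NC(=O)C4(C(=O)Nc5cccc(C(F)(F)F)c5)CC4)cc3)nc2n1C1CCCC1`, compound 2 `CN(C)C(=O)c1cc2cnc(Nc3ccc(NC(=O)C4(C(=O)Nc5cccc(Br)c5)CC4)cc3)nc2n1C1CCCC1` and compound 3 `Cc1ccc(NC(=O)C2(C(=O)Nc3ccc(Nc4ncc5cc(C(=O)N(C)C)n(C6CCCC6)c5n4)cc3)CC2)cc1`, which differ only in the aryl group on the amide-type nitrogen. In a functional assay on T47D cells (Homo sapiens) for inhibition, read by CCK-8 assay, with a stated time of 72 h, tested at 10 uM (a lower number here means less inhibition of growth, a higher number more inhibition of growth at the concentration tested), compound 1 gives 92.7%, compound 2 gives 94.6% and compound 3 gives 99.6%. Compound 3 sits at the top of these three numbers, but the steps of a number 6.9 percentage points higher from compound 1 to compound 3 (within the scatter) and a number 5 percentage points higher from compound 2 to compound 3 (within the scatter) are both within the scatter, as is a number 1.9 percentage points higher from compound 1 to compound 2 (within the scatter); the three aryl groups tried so far all give near-complete inhibition at the concentration tested. Compound 4 `CN(C)C(=O)c1cc2cnc(Nc3ccc(NC(=O)C4(C(=O)Nc5ccc(F)cc5)CC4)cc3)nc2n1C1CCCC1` is the next member of the series. Relative to compound 3 it shows (fluoro in place of methyl on an aromatic carbon). The measured steps that bear on this change are the three above, each of which exchanged the aryl group on the amide-type nitrogen without moving the number beyond the scatter. On that basis no step beyond the scatter is expected for compound 4 in this assay, the estimated step being a number 4.6 percentage points lower from compound 3 to compound 4 (within the scatter). Compound 4 is therefore expected to give about 95%, in the range 85% to 100%.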

Compound 4, percent growth inhibition at one concentration: 105%
The estimate for compound 4 lay 10 percentage points below the measured number; the whole stated range lies below it.
By their numbers in this assay, from the lowest: compounds 1, 2, 3 and 4 (each within the scatter of the next, the first and the last beyond it).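

In this assay, for the compounds shown here, the 4-fluorophenyl group on the amide-type nitrogen gives the first steps beyond the scatter, with a number 10.4 percentage points higher from compound 2 to compound 4 (beyond the scatter) and a number 12.3 percentage points higher from compound 1 to compound 4 (beyond the scatter) both modest in size. Fluoro in place of methyl on the aromatic carbon does not separate the two 4-substituted phenyl compounds, as a number 5.4 percentage points higher from compound 3 to compound 4 (within the scatter) shows, and compound 3, the 4-methylphenyl member, has no step beyond the scatter to any other compound, so the separation belongs to compound 4 alone. No measurement shown here gives a cause for these steps.

On these data alone, all four compounds sit at or near complete inhibition at a single concentration, so how far these aryl groups differ at lower concentrations remains open. Also open, as far as these compounds go, is whether a phenyl ring carrying an amine or a carboxylic acid, or a longer alkyl chain in place of the aryl group, would hold this level.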